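Removing the Side Chain Entirely

The source may report more compounds than this note shows. Statements on the series, on what has been measured and on what is new or still open speak of the compounds shown alone.

Measured so far in a functional assay on SKW 6.4 cells (Homo sapiens) for cytotoxicity; on this read-out lower numbers stand for stronger inhibition and higher numbers for weaker inhibition:
- compound 1 `CCCC/C=C/C1=C(CO)[C@H](O)[C@H]2O[C@H]2C1=O` gives 35000 nM.
- compound 2 `C/C=C/C1=C(CO)[C@H](O)[C@H]2O[C@H]2C1=O` reaches only the limit of this assay, > 80000 nM.
- compound 3 `C/C=C/C1=C(CO)[C@H](OC)[C@H]2O[C@H]2C1=O` also reaches only the limit of this assay, > 80000 nM.

Compound 2 therefore stands at the limit of this assay, where two of the three values sit (the limit of > 80000 nM in this assay, at which 2 of the 3 values shown sit). The unmeasured compound 4 `O=C1C=C(CO)[C@H](O)[C@H]2O[C@@H]12` differs from compound 2 by hydrogen in place of prop-1-en-1-yl on a double-bonded ring carbon. Among the measured compounds shown here, one measured step bears on this: an at least 2.2-fold higher number from compound 1 to compound 2 (0.35 log units; beyond the scatter), where shortening the chain already weakened inhibition. The step that the two limits leave unreadable from compound 2 to compound 3 gives no guidance. Removing the chain entirely is expected to weaken inhibition further or leave it at the limit, so the step that the limit leaves unreadable from compound 2 to compound 4 is expected to be small or unreadable. Compound 4 is therefore expected to give about 100000 nM, in the range 40000 nM to 300000 nM.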

Compound 4, half-maximal inhibitory concentration: > 80000 nM
Compound 4 was reported as a limit (the forecaster's own chance of this, stated with the estimate: 80%); the middle value lies beyond the limit too.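

Compound 2 and compound 4 both sit at the limit of this assay, so no step can be read between them: the limit of > 80000 nM in this assay, at which 3 of the 4 values shown sit.

On these data alone, whether replacing prop-1-en-1-yl with hydrogen changes inhibition at all stays open.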